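Working notes on a leukotriene B4 receptor 1 binding series

A few compounds are considered here, and "the series" means these few. Any claim that something is new, unique, unknown or untested is made for them only; others in the source may bear on it.

Measured compounds:
compound 1 `CCCCCCCCC(O)/C=C/c1cccc(CC(O)c2cccc(C(=O)O)c2)n1` — 1 nM
compound 2 `COc1ccc(CCCCCCCCOc2ccc(COc3cccc(C(=O)O)c3)[n+]([O-])c2/C=C/C(=O)O)cc1` — 150 nM
compound 3 `COc1ccc(CCCCCCCCOc2ccc(C[S+]([O-])c3cccc(CS(=O)(=O)C(F)(F)F)c3)nc2/C=C/C(=O)O)cc1` — 225 nM

In an assay for binding affinity to leukotriene B4 receptor 1 (Homo sapiens) (on this read-out higher numbers stand for weaker inhibition and lower numbers for stronger inhibition), compound 3 gives 225 nM, the highest of the three numbers. Compound 2 gives 150 nM in this assay, and the two values lie within the scatter of each other, so no order between compound 2 and compound 3 can be read from them. Compound 1 gives 1 nM, a far lower number, and that gap lies beyond the scatter.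

Compound 4 is `COc1ccc(CCCCCCCCOc2ccc(C[S+]([O-])c3cccc(OC)c3)nc2/C=C/C(=O)O)cc1`. The change from compound 3 is methoxy in place of ((trifluoromethyl)sulfonyl)methyl on an aromatic carbon. Within the data shown here, no measured pair in the set isolates this change, so the step has no precedent here. The expected step is a 1.8-fold higher number from compound 3 to compound 4 (0.25 log units; within the scatter), a modest move toward weaker binding that may well fall inside the scatter. Compound 4 is therefore estimated at 400 nM in this assay, with a range of 100 nM to 1500 nM.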

Compound 4, inhibition constant: 232 nM
The estimate for compound 4 lay 1.7-fold (0.24 log units) above the measured number, within the range that was stated.
By their numbers in this assay, from the lowest: compound 1; then compounds 2, 3 and 4 (each within the scatter of the next).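

In this assay, among these compounds, methoxy in place of ((trifluoromethyl)sulfonyl)methyl on an aromatic carbon gives a 1.0-fold higher number from compound 3 to compound 4 (0.01 log units; within the scatter) and is the first step confined to one place. On this six-membered aromatic ring of carbon only, meta to a large group, a substituent of 8 heavy atoms carrying fluorine and sulfur and one of 2 heavy atoms therefore read alike, so this exchange does not separate compound 3 from compound 4 on this read-out. Nothing measured here bears on the cause of this result.

On these data alone, whether an amine, a carboxylic acid or a longer alkyl chain on this same aromatic carbon would also read alike stays open. Also open, as far as these compounds go, is whether the same exchange would give a similar step on the core of compound 1.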